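The compounds below may be only part of what the source reports. "The series", "measured", "known", "first", "only" and "open" are said of these compounds alone.

Measured so far in an ADME assay on MDBK cells (Bos taurus) for cytotoxicity; on this read-out higher numbers stand for lower toxicity in this test and lower numbers for higher toxicity in this test
compound 1 `Cc1ccccc1Cn1ccc2nc(-c3ccccc3)nc-2c1` gives > 100000 nM as a limit
compound 2 `Clc1ccc(Cn2ccc3nc(-c4ccccc4)nc-3c2)cc1` gives > 100000 nM as a limit

Compound 2 stands with > 100000 nM in this assay and this is a limit, not a number. What the series offers so far is the limit of > 100000 nM in this assay, at which 2 of the 2 values shown sit, and nothing finer.

Compound 3 `N#Cc1ccc(Cn2ccc3nc(-c4ccccc4)nc-3c2)cc1` differs from compound 2 by one change (cyano in place of chloro on an aromatic carbon), cyano in place of chloro on an aromatic carbon, para to a large group. Within the data shown here, the only measured step that bears on it is a step that the two limits leave unreadable from compound 1 to compound 2 and it gives no size to carry over, though it concerns the same aromatic group. Among the measured compounds shown here, no step beyond the scatter is expected in this assay, and no direction is favoured, since the only guide is the limit of > 100000 nM in this assay, at which 2 of the 2 values shown sit, for the two measured compounds. The expected step is a number no higher from compound 2 to compound 3 (the limit leaves the size open) and a further limit is the likeliest report. For compound 3 the estimate is 100000 nM with an expected range from 50000 nM to 200000 nM in this read-out.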

Compound 3, half-maximal cytotoxic concentration: > 100000 nM
Compound 3: only a limit was reported; the forecaster's own chance of this, stated with the estimate: 80%; the middle value lies on the limit itself.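

Compound 3 adds no readable step to compound 1 and compound 2 in this assay, as all three are reported only as a limit, not a number: the limit of > 100000 nM in this assay, at which 3 of the 3 values shown sit.

The compounds shown leave open how far each lies beyond this limit, and whether any change to the aromatic group can shift the read-out.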